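The source may report more compounds than this note shows. Statements on the series, on what has been measured and on what is new or still open speak of the compounds shown alone.

Measured compounds in this assay:
compound 1 `Nc1nc(O)c2c(n1)n(C1OC(CO)[C@@H](O)[C@H]1O)c(=O)n2Cc1ccc(Cl)c(Cl)c1`: 55%
compound 2 `CCCCCCCCCCn1c(=O)n(C2OC(CO)[C@@H](O)[C@H]2O)c2nc(N)nc(O)c21`: 0%

In a functional assay on the whole organism (B cells) with Mus musculus as the target (a lower number here means a smaller maximal response, a higher number a larger maximal response), compound 2 stands at the lowest of these two numbers. Within the data shown here, the only known step is a number 55 percentage points lower from compound 1 to compound 2 (beyond the scatter), a large drop when nonyl replaced 3,4-dichlorophenyl. Compound 3 `Cn1c(=O)n(C2OC(CO)[C@@H](O)[C@H]2O)c2nc(N)nc(O)c21` differs from compound 2 by hydrogen in place of nonyl on a saturated chain carbon bound to an aromatic nitrogen. That one step bears only loosely here, since it does not trade nonyl for hydrogen. The expected step is therefore small, a number 10 percentage points higher from compound 2 to compound 3 (within the scatter), within the usual scatter. Compound 3 is expected to give 10%, in the range 0% to 45%.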

Compound 3, largest response reached (reported as maximal response), in percent of the reference or control that the assay uses: 99%
Compound 3: middle estimate off by 89 percentage points, on the low side; measured number above the stated range.
By their numbers in this assay, from the lowest: compound 2; then compound 1; then compound 3.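

In this assay, trading decyl for methyl gives a number 99 percentage points higher from compound 2 to compound 3 (beyond the scatter), and hydrogen in place of 3,4-dichlorophenyl gives a number 44 percentage points higher from compound 1 to compound 3 (beyond the scatter). This position therefore needs neither the long chain nor the dichlorophenyl group for a response, and the methyl compound reaches the highest of the three numbers, with both steps to it beyond the scatter. No measurement shown explains why. Still open, from the compounds shown here alone, is whether a propyl or butyl chain would fall between methyl and decyl, and how a chain ending in an amine or a carboxylic acid would behave.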